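The source may report more compounds than this note shows. Statements on the series, on what has been measured and on what is new or still open speak of the compounds shown alone.

Of the compounds shown here, three sharing one core have been measured in a functional assay on MIA PaCa-2 cells (Homo sapiens) for inhibition, read by MTT assay, with a stated time of 48 h, tested at 10 uM; on this read-out higher numbers stand for more inhibition of growth at the one concentration tested and lower numbers for less inhibition of growth. Compound 1 `O=C(/C=C/c1ccc(OCc2cn(Cc3ccccc3Br)nn2)cc1)c1ccc(Br)cc1` gives 43% in this assay. Compound 2 `O=C(/C=C/c1ccc(OCc2cn(Cc3ccc(Br)cc3)nn2)cc1)c1ccc(Br)cc1` gives 29%, and compound 3 `O=C(/C=C/c1ccc(OCc2cn(Cc3cccc(F)c3)nn2)cc1)c1ccc(Br)cc1` gives 34%. Compound 2 stands with the lowest of the three numbers: the change a number 14 percentage points lower from compound 1 to compound 2 (beyond the scatter) lies beyond the scatter, while the gap a number 5 percentage points higher from compound 2 to compound 3 (within the scatter) does not, so compound 2 and compound 3 cannot be set in order against each other.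

Compound 4 `O=C(/C=C/c1ccc(OCc2cn(Cc3ccc(Br)cc3)nn2)cc1)c1ccc([N+](=O)[O-])cc1` is the next compound to be measured. The difference from compound 2 is nitro in place of bromo on an aromatic carbon. For the measured compounds named here, none of the measured steps bears on this position: each of a number 14 percentage points lower from compound 1 to compound 2 (beyond the scatter), a number 9 percentage points lower from compound 1 to compound 3 (within the scatter) and a number 5 percentage points higher from compound 2 to compound 3 (within the scatter) alters the group on a saturated chain carbon bound to an aromatic nitrogen, on the other side of the core, and the group on the six-membered aromatic ring of carbon only that carries the carbonyl is the same in all three measured compounds. The measured data therefore give no direction for the new change. The expectation for compound 4 is a step of a number 1 percentage points higher from compound 2 to compound 4 (within the scatter), that is, no step beyond the scatter. Compound 4 is estimated at 30%, within a range from 15% to 45%.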

Compound 4, percent growth inhibition at one concentration: 17%
Compound 4: middle estimate off by 13 percentage points, on the high side; measured number inside the range.
By their numbers in this assay, from the lowest: compound 4; then compounds 2, 3 and 1 (each within the scatter of the next, the first and the last beyond it).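

The 4-bromophenyl to 4-nitrophenyl change on the carbonyl gives a number 12 percentage points lower from compound 2 to compound 4 (beyond the scatter) in this assay, so the position para to a large group on this ring is not silent: a change here alone carries the number beyond the scatter, towards less inhibition of growth. For the compounds shown here, until now, only the group on the saturated chain carbon bound to an aromatic nitrogen had been varied, and the one step beyond the scatter there was a number 14 percentage points lower from compound 1 to compound 2 (beyond the scatter); both ends of the molecule can now be said to move this read-out, though this position rests on a single pair of compounds. No measurement at hand accounts for the step.

The compounds shown leave open whether the lower number is particular to nitro or would also follow from another replacement for bromo at this position, such as an amine, a carboxylic acid or a methoxy group. They also leave open whether nitro in place of bromo would give a similar step in the setting of compound 1 or compound 3, which carry other groups on the saturated chain carbon.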